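Taking the Bromo Off Compound 2

The source may hold more compounds than are shown below. What is called first, only, known or untested is meant among the compounds shown, and "the series" means these compounds.

Measured in a functional assay on HeLa cells (Homo sapiens) for cytotoxicity, read by MTT assay, with a stated time of 48 h; on this read-out higher numbers stand for weaker inhibition and lower numbers for stronger inhibition:
- compound 1 `O=C(O)CN1C(=O)/C(=C/c2nc3ccccc3n2Cc2ccc(Br)cc2)SC1=S`: 12900 nM
- compound 2 `O=C(O)CN1C(=O)/C(=C/c2nc3ccccc3n2Cc2ccc(Br)cc2F)SC1=S`: > 50000 nM (a limit)
- compound 3 `N#Cc1ccc(Cn2c(/C=C3\SC(=S)N(CC(=O)O)C3=O)nc3ccccc32)cc1`: 16300 nM

Compound 2 is known only by a limit, > 50000 nM. This is the limit of > 50000 nM in this assay, at which 1 of the 3 values shown sits. Compound 4 `O=C(O)CN1C(=O)/C(=C/c2nc3ccccc3n2Cc2ccccc2F)SC1=S` differs from it by one change, hydrogen in place of bromo on an aromatic carbon. Going by the values given here, no measured step makes this exact change. The nearest is a 1.3-fold higher number from compound 1 to compound 3 (0.10 log units; within the scatter), where cyano replaces bromo and nothing moves beyond the scatter. Compound 4 keeps the fluoro group, and adding fluoro gave an at least 3.8-fold higher number from compound 1 to compound 2 (0.58 log units; beyond the scatter). Replacing the whole 4-bromo-2-fluorophenyl group gave an at least 3.0-fold lower number from compound 2 to compound 3 (0.48 log units; beyond the scatter), but that step also removes the fluoro. A modest move toward lower numbers in this assay is therefore expected, and compound 4 may also end up at the limit. The expected change is an at least 1.4-fold lower number from compound 2 to compound 4 (0.15 log units; that floor lies within the scatter). For compound 4 the estimated value is 35000 nM, within an expected range from 14000 nM to 75000 nM.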

Compound 4, half-maximal inhibitory concentration: 640 nM
The estimate for compound 4 lay 55-fold (1.74 log units) above the measured number, outside the stated range (below it).
By their numbers in this assay, from the lowest: compound 4; then compounds 1 and 3 (each within the scatter of the next). At a limit, above all of these: compound 2.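

In this assay, taking the bromo off the aromatic carbon para to a large group while keeping the fluoro group gave an at least 78-fold lower number from compound 2 to compound 4 (1.89 log units; beyond the scatter), so this position matters far more than the swap of bromo for cyano, made without the fluoro group, had suggested. The step starts from a value that is only a limit, so its true size is unknown: the limit of > 50000 nM in this assay, at which 1 of the 4 values shown sits.

The fluoro group, which came with the loss of activity in compound 2, is also present in compound 4, which outdoes both compounds lacking it, with a 25-fold lower number from compound 3 to compound 4 (1.41 log units; beyond the scatter) and a 20-fold lower number from compound 1 to compound 4 (1.30 log units; beyond the scatter).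

From the compounds shown here alone, what stays open is how a plain benzyl group, with neither bromo nor fluoro, would read, and so whether the fluoro group contributes to the low number of compound 4 at all. Also open, going by these compounds, is how a methoxy group or an amine would read at this position.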